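Aryl variation on the saturated carbon of the shared core

The source may hold more compounds than are shown below. What is called first, only, known or untested is meant among the compounds shown, and "the series" means these compounds.

Compound 1 `CNC(=O)c1cc(Oc2ccc(C3=NNC(c4ccc(C#N)cc4)C3)cc2)ccn1` gives 9910 nM in a functional assay on PC-3 cells (Homo sapiens) for cytotoxicity, read by MTT assay, with a stated time of 72 h; a higher number here means a weaker inhibitor, a lower number a stronger inhibitor. Compound 2 `CNC(=O)c1cc(Oc2ccc(C3=NNC(c4ccc(F)cc4Cl)C3)cc2)ccn1` gives 24300 nM in this assay, and the swap of aryl groups on the saturated ring carbon shows a 2.5-fold higher number from compound 1 to compound 2 (0.39 log units; beyond the scatter). Compound 3 `CNC(=O)c1cc(Oc2ccc(C3=NNC(c4cccc([N+](=O)[O-])c4)C3)cc2)ccn1` gives "not determined" (no result reported) in this assay, so it gives no anchor. Compound 4 `CNC(=O)c1cc(Oc2ccc(C3=NNC(c4ccc(F)cc4)C3)cc2)ccn1` differs from compound 3 in one place: 4-fluorophenyl in place of 3-nitrophenyl on a saturated ring carbon. Among the compounds with values here, only the step between compound 1 and compound 2 bears on this change, and it was modest; with no number for compound 3, the size of the step from compound 3 to compound 4 in this assay cannot be set, and a value between those of compound 1 and compound 2 is expected. The value of compound 4 in this assay is estimated at 15000 nM, with a range of 5000 nM to 50000 nM.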

Compound 4, half-maximal inhibitory concentration: 6770 nM
Compound 4: middle estimate off by 2.2-fold (0.35 log units), on the high side; the measured number falls inside the stated range.
By their numbers in this assay, from the lowest: compounds 4 and 1 (each within the scatter of the next); then compound 2.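

In this assay, hydrogen in place of chloro on an aromatic carbon gives a 3.6-fold lower number from compound 2 to compound 4 (0.56 log units; beyond the scatter), so the chloro group of compound 2 separates it from compound 4 on this aryl ring. Fluoro in place of cyano on an aromatic carbon gives a 1.5-fold lower number from compound 1 to compound 4 (0.17 log units; within the scatter), so this exchange does not separate the two compounds. No data on hand explain either step. Open, as far as these compounds go, is where a methoxy group, an amine or a carboxylic acid on this aryl ring would stand in this assay, and whether a chloro group has the same effect on other aryl groups.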